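Hydrogen for methyl on the aryl oxygen, two cores

This account rests on a few compounds, and the source may have more. Where it says the series, first, only, none or still open, it means among the compounds named here.

Compound 1 `CCc1cc2cc(OC)cc(C(=O)c3ccc(OC)cc3)c2o1` and compound 2 `CCc1oc2cc(OC)ccc2c1C(=O)c1ccc(OC)cc1` are built from the same atoms joined differently; the difference between the two cores is not broken down here. In an assay for inhibition of solute carrier family 22 member 12 (Homo sapiens), read by scintillation counting, with a stated time of 60 min, tested at 50 uM (a higher number here means more inhibition at the concentration tested (going by the name of the read-out), a lower number less inhibition), compound 1 gives 5.2% and compound 2 gives 6.2%, two numbers that lie within the scatter of each other. Compound 3 `CCc1cc2cc(O)cc(C(=O)c3ccc(OC)cc3)c2o1` carries hydrogen in place of methyl on an oxygen on an aromatic ring relative to compound 1, and in this assay compound 3 gives 9.3%; the step of a number 4.1 percentage points higher from compound 1 to compound 3 (within the scatter) is within the scatter. Compound 4 `CCc1oc2cc(O)ccc2c1C(=O)c1ccc(OC)cc1` is not yet measured and differs from compound 2 by hydrogen in place of methyl on an oxygen on an aromatic ring, the same kind of change as from compound 1 to compound 3, with the place described in the same words in both cases. The change occurs twice among these four compounds. Among the measured compounds shown here, the expectation for compound 4 in this assay rests on compound 2 at 6.2% and on the single measured step of a number 4.1 percentage points higher from compound 1 to compound 3 (within the scatter). On that basis the expected step is a number 3.8 percentage points higher from compound 2 to compound 4 (within the scatter), again within the scatter. Compound 4 is estimated at 10%, between 2% and 19%.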

Compound 4, a percentage reported as inhibition, at one concentration (the size of the read-out at that concentration, not a potency): 48.3%
Compound 4: the middle estimate sits 38.3 percentage points below what was measured; the measured number lies above the stated range.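

In this assay the change from methoxy to hydroxy gives a number 42.1 percentage points higher from compound 2 to compound 4 (beyond the scatter). The size of this step does not carry over between the two cores, and a step read on one of them is a poor guide to the other in this series: the same change on two cores in this assay, a number 4.1 percentage points higher (within the scatter) from compound 1 to compound 3 and a number 42.1 percentage points higher (beyond the scatter) from compound 2 to compound 4, 38 percentage points apart, beyond the scatter of two such steps The comparison rests on one pair per core, read at a single concentration; it gives no potency, assigns no cause to the gap, and says nothing about how the change would behave on any third core.

The compounds shown carry only methoxy or hydroxy on this oxygen, so it remains open how an ethoxy group or an amine in place of the hydroxy would read in this assay on the core of compound 4. Also open, as far as these compounds go, is whether the large step persists when a longer chain replaces the ethyl group on that core.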